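The source may hold more compounds than are shown below. What is called first, only, known or untested is meant among the compounds shown, and "the series" means these compounds.

Compound 1 `C[S+]([O-])/C=C/c1cc(=O)c2ccccc2o1` gives 1900 nM in a functional assay on A549 cells (Homo sapiens) for cytotoxicity, with a stated time of 48 h; a lower number here means a stronger inhibitor, a higher number a weaker inhibitor.
Compound 2 `Cc1c(/C=C/[S+](C)[O-])oc2ccccc2c1=O` gives 1500 nM in this assay.
Compound 3 `COc1ccc2c(=O)cc(/C=C/[S+](C)[O-])oc2c1` gives 2200 nM in this assay.

On these numbers compound 1 stands second highest of three, with compound 3 nearest and compound 2 furthest, and both of them sit within the scatter of compound 1, so no order among the three can be claimed. Compound 4 `C[S+]([O-])/C=C/c1cc(=O)c2cc(OC(=O)C(C)(C)C)ccc2o1` is the unmeasured partner, and its change from compound 1 is ((tert-butyl)carbonyl)oxy in place of hydrogen on an aromatic carbon. Among the compounds with values here, the steps that bear on it are the two other substitutions of a hydrogen on an aromatic carbon of the shared core: a 1.3-fold lower number from compound 1 to compound 2 (0.10 log units; within the scatter) and a 1.2-fold higher number from compound 1 to compound 3 (0.06 log units; within the scatter). Neither moved the number beyond the scatter, though both groups differ from the one entering here. The expected step is therefore no change at the digits printed from compound 1 to compound 4 (within the scatter), with no direction claimed. Compound 4 is estimated at 1900 nM, within 800 nM to 4500 nM.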

Compound 4, half-maximal inhibitory concentration: 1600 nM
Estimate against measurement, compound 4: 1.2-fold (0.07 log units) above; the range from low to high includes it.
By their numbers in this assay, from the lowest: compounds 2, 4, 1 and 3 (each within the scatter of the next).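

Putting ((tert-butyl)carbonyl)oxy on this aromatic carbon of the shared core gives a 1.2-fold lower number from compound 1 to compound 4 (0.07 log units; within the scatter). Within the data shown here, the earlier steps involved only methyl and methoxy at other places on the core, so this is the first sign that this place can carry a group of 7 heavy atoms without the number leaving the scatter. No measurement here explains why the number holds.

From the compounds shown here alone, whether a smaller group such as hydroxyl, or an amine or a carboxylic acid, would leave the number equally unmoved at this place remains open.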